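The source may report more compounds than this note shows. Statements on the series, on what has been measured and on what is new or still open speak of the compounds shown alone.

In an ADME assay on L929 cells (Mus musculus) for cytotoxicity, read by resazurin assay, with a stated time of 96 h (on this read-out lower numbers stand for higher toxicity in this test and higher numbers for lower toxicity in this test), compound 1 (`NC(=S)N/N=C(\COc1ccccc1)c1ccc(Br)cc1`) gives 54900 nM. In the same test, compound 2 (`CC(C)(C)c1ccc(OC/C(=N\NC(N)=S)c2ccc(Br)cc2)cc1`) gives 23800 nM and compound 3 (`CC(=O)Nc1ccc(OC/C(=N\NC(N)=S)c2ccc(Br)cc2)cc1`) gives 94900 nM. Compound 1 and compound 3 lie within the scatter of each other, whereas compound 2 has the lowest number of the three.

Compound 4 (`NC(=S)N/N=C(\COc1cccc(Cl)c1)c1ccc(Br)cc1`) keeps the core of compound 1 and differs from it in one place: chloro in place of hydrogen on an aromatic carbon. In words, this is chloro in place of hydrogen on an aromatic carbon, or phenyl to 3-chlorophenyl.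

Two measured steps also replace hydrogen on an aromatic carbon. The tert-butyl replacement comes with a 2.3-fold lower number from compound 1 to compound 2 (0.36 log units; beyond the scatter), while the acetamido replacement comes with a 1.7-fold higher number from compound 1 to compound 3 (0.24 log units; within the scatter). The two substituents also stand apart from each other, with a 4.0-fold higher number from compound 2 to compound 3 (0.60 log units; beyond the scatter). Among the compounds with values here, no measured compound carries chloro, so these steps offer only a loose guide, and they do not share a direction.

A small move towards a lower number in this assay is expected, not exceeding the scatter. The expected step is a 1.3-fold lower number from compound 1 to compound 4 (0.11 log units; within the scatter). For compound 4, the estimated value is 43000 nM, with an expected range from 21000 nM to 80000 nM.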

Compound 4, half-maximal cytotoxic concentration: < 50200 nM
Compound 4 was reported as a limit; the forecaster's own chance of this, stated with the estimate: 3%; the middle value does not contradict the limit.
By their numbers in this assay, from the lowest: compound 2; then compounds 1 and 3 (each within the scatter of the next).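

In this assay compound 4 stands as a limit, < 50200 nM, and not as a number. Read as a step, that limit gives an at least 1.0-fold lower number from compound 1 to compound 4 (0.03 log units; that floor lies within the scatter), so the change from phenyl to 3-chlorophenyl, with chloro meta to a large group, fixes only a floor: the true step could stay within the scatter or go beyond it, and the floor does not tell which. Unlike the tert-butyl and acetamido steps, which have measured sizes, this step has an open end, and compound 4 is the only compound shown that is reported in this way: the limit of < 50200 nM in this assay, at which 1 of the 4 values shown sits.

As far as these compounds go, how far compound 4 lies past its limit stays open, so its place relative to compound 2 and compound 3 cannot be settled, and the order of the series remains incomplete. The compounds shown also leave open how fluoro, methoxy or an amine would read at this same place on the ring, and whether a number rather than a limit would be obtained for any of them.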